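Phenyl for Methyl on the Amine of Compound 1

This account rests on a few compounds, and the source may have more. Where it says the series, first, only, none or still open, it means among the compounds named here.

Measured so far:
- Compound 1, `CCOc1ccc(-n2nnc3n[nH]c(NC)c3c2=O)cc1`: 7010 nM
- Compound 2, `C=CCNc1[nH]nc(N)c1C(=O)Nc1ccc(OCC)cc1`: 22000 nM

In a functional assay on Huh-7 cells (Homo sapiens) for cytotoxicity, read by resazurin assay, with a stated time of 48 h (on this read-out higher numbers stand for weaker inhibition and lower numbers for stronger inhibition), compound 1 gives 7010 nM. This is the lowest of the two numbers, so compound 1 is the stronger of the pair; compound 2 gives 22000 nM, a gap that lies beyond the usual scatter. The two compounds share no single-point difference, so only their two values can be compared. Compound 3, `CCOc1ccc(-n2nnc3n[nH]c(Nc4ccccc4)c3c2=O)cc1`, has not yet been measured. It differs from compound 1 in one place: phenyl in place of methyl on a nitrogen on an aromatic ring. Going by the values given here, no measured pair shows what such a change does here, so there is nothing to lean on beyond the value of compound 1 itself. A modest step toward a lower number is expected, roughly a 1.8-fold lower number from compound 1 to compound 3 (0.24 log units; within the scatter), close to the edge of the scatter. Compound 3 is therefore estimated at 4000 nM, within a range from 1500 nM to 12000 nM.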

Compound 3, half-maximal inhibitory concentration: 9390 nM
Compound 3: the middle estimate sits 2.3-fold (0.37 log units) below what was measured, and the stated range covers the measured number.
By their numbers in this assay, from the lowest: compounds 1 and 3 (each within the scatter of the next); then compound 2.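

In this assay, the change from methylamino to anilino gives a 1.3-fold higher number from compound 1 to compound 3 (0.13 log units; within the scatter), which lies within the usual scatter, so the two compounds cannot be told apart. Going by these compounds alone, this is the first direct reading at this nitrogen, and it shows that replacing methyl with phenyl, which adds a six-membered aromatic ring and raises the group from 1 heavy atom to 6, leaves the number unchanged within that scatter. Nothing measured here explains why the larger group makes no clear difference. One step with a single aromatic group cannot show how much freedom this position allows overall. Going by these compounds, it remains open whether a benzyl group or a longer chain such as butyl on this nitrogen would behave like phenyl, and whether a carboxylic acid or an amine carried on the phenyl ring would shift the number beyond the scatter.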